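A few compounds are considered here, and "the series" means these few. Any claim that something is new, unique, unknown or untested is made for them only; others in the source may bear on it.

Measured compounds:
compound 1 `Clc1ccc(-c2nc3ncccc3o2)cc1`, 24%;
compound 2 `Fc1ccc(-c2nc3ncccc3o2)cc1`, 28%;
compound 3 `FC(F)(F)Oc1ccc(-c2nc3ncccc3o2)cc1`, 0%.

In a functional assay on the whole organism for inhibition, with Rattus norvegicus as the target, at a dose of 30 mg/kg (a lower number here means less inhibition, a higher number more inhibition at the dose given (going by the name of the read-out)), compound 2 gives the highest of the three numbers, though compound 1 sits within the scatter of it, as a number 4 percentage points higher from compound 1 to compound 2 (within the scatter) shows. Compound 3 falls well short of both: a number 24 percentage points lower from compound 1 to compound 3 (beyond the scatter) and a number 28 percentage points lower from compound 2 to compound 3 (beyond the scatter). Compound 4 `Fc1ccc(-c2nc3ncccc3o2)c(F)c1` is not yet measured; it carries fluoro in place of hydrogen on an aromatic carbon. Within the data shown here, no measured step adds a second fluoro; the only small-halogen step, a number 4 percentage points higher from compound 1 to compound 2 (within the scatter), stayed within the scatter, while the larger trifluoromethoxy steps were modest. He therefore expects a number 3 percentage points lower from compound 2 to compound 4 (within the scatter), no step beyond the scatter, and estimates that compound 4 gives 25%, between 8% and 42%, in this assay.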

Compound 4, a percentage reported as inhibition, in the whole organism at one dose (the size of the read-out at that dose, not a potency): 23%
Estimate against measurement, compound 4: 2 percentage points above; measured number inside the range.
By their numbers in this assay, from the lowest: compound 3; then compounds 4, 1 and 2 (each within the scatter of the next).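

In this assay fluoro in place of hydrogen, on the aromatic carbon ortho to a group of 9 heavy atoms, gives a number 5 percentage points lower from compound 2 to compound 4 (within the scatter) and so leaves the number unresolved from that of the parent. The earlier compounds shown here each carried one group on that ring, whereas compound 4 shows that a second fluoro can stand at this new place without a step beyond the scatter. Nothing given here explains this result.

The compounds shown leave open what an amine or a carboxylic acid would do at this same position. They also leave open whether a chloro there would behave as this fluoro does.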